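The compounds below may be only part of what the source reports. "The series", "measured", "known", "first", "only" and "open" are said of these compounds alone.

Compound 3 `O=C(NCc1cc(Cl)ccc1-n1cnnn1)[C@@H]1C[C@@H]2C[C@@H]2N1C(=O)[C@H](O)c1ccccc1` carries a phenyl on a saturated chain carbon bound to a carbonyl carbon and an oxygen on a saturated carbon. In an ADME assay on liver for metabolic stability, with Liver microsome (Homo sapiens) as the target, read by LC-MS, using microsomes (on this read-out higher numbers stand for fast clearance and lower numbers for slow clearance), compound 3 gives < 16 mL.min-1.g-1, which is a limit of the assay and not a number (the limit of < 16 mL.min-1.g-1 in this assay, at which 1 of the 3 values shown sits). Compound 1 `O=C(NCc1cc(Cl)ccc1-n1cnnn1)[C@@H]1C[C@@H]2C[C@@H]2N1C(=O)[C@H](O)c1cccc(Cl)c1` differs from it by chloro on an aromatic carbon; in this assay compound 1 gives > 500 mL.min-1.g-1, again a limit (the limit of > 500 mL.min-1.g-1 in this assay, at which 1 of the 3 values shown sits). The step of an at least 31-fold lower number from compound 1 to compound 3 (1.49 log units; beyond the scatter) is large. Compound 2 `O=C(NCc1cc(Cl)ccc1-n1cnnn1)[C@@H]1C[C@@H]2C[C@@H]2N1C(=O)[C@H](O)CC1CC1` carries cyclopropylmethyl in the place of the phenyl; in this assay compound 2 gives < 12 mL.min-1.g-1, also a limit (the limit of < 12 mL.min-1.g-1 in this assay, at which 1 of the 3 values shown sits). The step of an at least 41-fold lower number from compound 1 to compound 2 (1.61 log units; beyond the scatter) is likewise large, whereas the step that the two limits leave unreadable from compound 2 to compound 3 is left unreadable by the two limits.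

Compound 4 `CC(C)(C)[C@@H](O)C(=O)N1[C@H](C(=O)NCc2cc(Cl)ccc2-n2cnnn2)C[C@@H]2C[C@@H]21` differs from compound 3 by tert-butyl in place of phenyl on a saturated chain carbon bound to a carbonyl carbon and an oxygen on a saturated carbon. Among the measured compounds shown here, the only measured step that bears on this kind of exchange is a step that the two limits leave unreadable from compound 2 to compound 3, and it gives no size; all that can be said is that the saturated group in compound 2 left it at a limit < 12 mL.min-1.g-1. Compound 4 is therefore expected to stay slow, at an estimated 10 mL.min-1.g-1 (range 3 mL.min-1.g-1 to 30 mL.min-1.g-1), an expected step that the limit leaves unreadable from compound 3 to compound 4 that would not exceed the scatter.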

Compound 4, intrinsic clearance in microsomes: 75 mL.min-1.g-1
For compound 4 the middle estimate is 7.5-fold (0.88 log units) below the measured one; measured number outside the range, above it.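

At this position a saturated group does not by itself keep the number low in this assay: tert-butyl in place of cyclopropylmethyl gives an at least 6.2-fold higher number from compound 2 to compound 4 (0.79 log units; beyond the scatter), and tert-butyl in place of phenyl gives an at least 4.6-fold higher number from compound 3 to compound 4 (0.67 log units; beyond the scatter). Tert-butyl in place of 3-chlorophenyl still gives an at least 6.6-fold lower number from compound 1 to compound 4 (0.82 log units; beyond the scatter), so the group now stands apart from all three others, and the exchange at this one place moves the read-out in both directions, with each of these steps resting on a limit of the assay at one end and not on two numbers. Nothing given here accounts for why tert-butyl parts from cyclopropylmethyl and phenyl.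

The compounds shown leave open how isopropyl or cyclohexyl would read on this saturated chain carbon, and so whether the higher number belongs to tert-butyl alone or extends to other branched or larger saturated groups. They also leave open how 4-chlorophenyl or a pyridyl would read here, and whether an amine in this place would hold the number down as phenyl does.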